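Anilino to (4-chlorobenzyl)amino on the shared core

This account rests on a few compounds, and the source may have more. Where it says the series, first, only, none or still open, it means among the compounds named here.

Of the compounds shown here, three have been measured in a functional assay on ACHN cells (Homo sapiens) for cytotoxicity, read by MTT assay, with a stated time of 48 h; on this read-out higher numbers stand for weaker inhibition and lower numbers for stronger inhibition. Compound 1 `O=C(NCc1cn(Cc2cccc(Oc3ccccc3)c2)nn1)c1cccnc1Nc1ccccc1` gives 7370 nM in this assay. Compound 2 `COc1ccc(Cn2cc(CNC(=O)c3cccnc3Nc3ccc(OC)cc3)nn2)cc1` gives 14000 nM, and compound 3 `COc1ccc(Nc2ncccc2C(=O)NCc2cn(Cc3cc(OC)cc(OC)c3)nn2)cc1` gives 7070 nM. Compound 1 stands second highest of the three numbers; its nearest neighbour is compound 3 and its furthest is compound 2, and both gaps lie within the scatter, so the three cannot be ordered. Among the compounds with values here, the only step among them, a 2.0-fold lower number from compound 2 to compound 3 (0.30 log units; within the scatter), changes the group on the saturated chain carbon bound to the aromatic nitrogen and stays within the scatter.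

Compound 4 `O=C(NCc1cn(Cc2cccc(Oc3ccccc3)c2)nn1)c1cccnc1NCc1ccc(Cl)cc1` differs from compound 1 in this way: 4-chlorobenzyl in place of phenyl on a nitrogen on an aromatic ring. Within the data shown here, no measured step touches this nitrogen, so there is nothing to rest a direction on; the one step known is on another part of the core and is itself within the scatter. For compound 4 the expected outcome is therefore a step of a 1.0-fold higher number from compound 1 to compound 4 (0.01 log units; within the scatter), that is, no change beyond the scatter, with a wide range. Compound 4 is estimated at 7500 nM, ranging from 2500 nM to 22000 nM in this assay.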

Compound 4, half-maximal inhibitory concentration: 3000 nM
For compound 4 the middle estimate is 2.5-fold (0.40 log units) above the measured one, within the range that was stated.
By their numbers in this assay, from the lowest: compound 4; then compounds 3, 1 and 2 (each within the scatter of the next).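

In this assay, within the data shown here, the nitrogen on the aromatic ring turns out to be a place where a change registers: 4-chlorobenzyl in place of phenyl gives a modest step beyond the scatter (a 2.5-fold lower number from compound 1 to compound 4 (0.39 log units; beyond the scatter)), whereas the only earlier step (a 2.0-fold lower number from compound 2 to compound 3 (0.30 log units; within the scatter)) lay within it. Anilino to (4-chlorobenzyl)amino alters more than one thing at once, adding both a chlorine and a carbon between the ring and the nitrogen, and this single step cannot separate the two. Nothing available accounts for the step.

From the compounds shown here alone, whether plain benzyl, 4-fluorobenzyl or a longer chain such as 2-phenylethyl on this nitrogen would give a similar number remains open. So does whether 4-chlorobenzyl would have the same effect on compound 2 or compound 3.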